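This account rests on a few compounds, and the source may have more. Where it says the series, first, only, none or still open, it means among the compounds named here.

Measured so far:
compound 1, `Nc1nc(Cc2cccc(C(F)(F)F)c2)nc2cn(-c3ccccc3)nc12`: 41%
compound 2, `Nc1nc(Cc2ccccc2Cl)nc2cn(-c3ccccc3)nc12`: 22%
compound 3, `Nc1nc(Cc2cccc(Cl)c2)nc2cn(-c3ccccc3)nc12`: 42%

In an assay on CHO cells for displacement of a labelled ligand from adenosine receptor A3 (Homo sapiens), read by scintillation counting, tested at 1 uM (on this read-out higher numbers stand for more inhibition at the one concentration tested (going by the name of the read-out) and lower numbers for less inhibition), compound 3 gives the highest of the three numbers shown, though its gap to compound 1, a number 1 percentage points higher from compound 1 to compound 3 (within the scatter), is not a real difference; only the gap to compound 2, a number 20 percentage points higher from compound 2 to compound 3 (beyond the scatter), lies beyond the scatter. Compound 4, `Nc1nc(CCc2ccc(O)cc2)nc2cn(-c3ccccc3)nc12`, differs from compound 3 by 4-hydroxybenzyl in place of 3-chlorophenyl on a saturated chain carbon bound to an aromatic carbon. Of the measured steps, a number 20 percentage points higher from compound 2 to compound 3 (beyond the scatter) shows that 3-chlorophenyl in place of 2-chlorophenyl shifted the number modestly, while a number 1 percentage points higher from compound 1 to compound 3 (within the scatter) shows that chloro in place of trifluoromethyl did not. Neither step covers a hydroxyl or a longer link, so the guidance is thin; a modest downward step, a number 17 percentage points lower from compound 3 to compound 4 (beyond the scatter), is expected. Compound 4 is estimated at 25%, within 8% to 45%.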

Compound 4, a percentage reported as inhibition, at one concentration (the size of the read-out at that concentration, not a potency): 37%
Compound 4: middle estimate off by 12 percentage points, on the low side; the range from low to high includes it.
By their numbers in this assay, from the lowest: compound 2; then compounds 4, 1 and 3 (each within the scatter of the next).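

On the saturated chain carbon, 4-hydroxybenzyl can stand in for 3-chlorophenyl: a number 5 percentage points lower from compound 3 to compound 4 (within the scatter) is no real change, even though the entering group brings a hydroxyl, a hydrogen-bond donor that 3-chlorophenyl lacks. a number 15 percentage points higher from compound 2 to compound 4 (beyond the scatter) also places 4-hydroxybenzyl above 2-chlorophenyl, so compound 2 stays apart from both compound 3 and compound 4. No measured evidence explains this behaviour. On these data alone, whether an amine or a carboxylic acid in place of the hydroxyl would hold the number remains open, as does the effect of a longer chain.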